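One added nitro on an inactive urea

The source may report more compounds than this note shows. Statements on the series, on what has been measured and on what is new or still open speak of the compounds shown alone.

Measured in a functional assay on HL-60 cells (Homo sapiens) for inhibition, read by CCK-8 assay, with a stated time of 48 h; on this read-out higher numbers stand for weaker inhibition and lower numbers for stronger inhibition:
- Compound 1 `O=C(NCCNS(=O)(=O)c1ccc(-c2ccccc2Oc2ccc([N+](=O)[O-])c([N+](=O)[O-])c2)s1)Nc1cc(Cl)cc(Cl)c1`: 2300 nM
- Compound 2 `COc1ccc(NC(=O)NCCNS(=O)(=O)c2ccc(-c3ccccc3Oc3ccc([N+](=O)[O-])cc3)s2)cc1`: > 50000 nM (a limit, not a number)

Compound 2 yields no number and stands at the limit of > 50000 nM in this assay, at which 1 of the 2 values shown sits. Compound 3 `COc1ccc(NC(=O)NCCNS(=O)(=O)c2ccc(-c3ccccc3Oc3ccc([N+](=O)[O-])c([N+](=O)[O-])c3)s2)cc1` departs from compound 2 by one change, nitro in place of hydrogen on an aromatic carbon, turning 4-nitrophenyl into 3,4-dinitrophenyl. Within the data shown here, no measured step isolates this change. Compound 1 also carries 3,4-dinitrophenyl and gives 2300 nM, so a shift toward stronger inhibition is expected. The expected step is an at least 5.5-fold lower number from compound 2 to compound 3 (0.74 log units; beyond the scatter). Compound 3 is estimated at 9000 nM, with an expected range of 2500 nM to 40000 nM, in this assay.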

Compound 3, half-maximal inhibitory concentration: 5400 nM
Beside the measured number, compound 3's estimate is 1.7-fold (0.22 log units) above it; low and high end bracket the measured number.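

Turning 4-nitrophenyl into 3,4-dinitrophenyl, with the new nitro ortho to the first, brings the urea into measurable range in this assay: an at least 9.2-fold lower number from compound 2 to compound 3 (0.96 log units; beyond the scatter). The starting value of compound 2 is a limit, not a number: the limit of > 50000 nM in this assay, at which 1 of the 3 values shown sits.

With 3,4-dinitrophenyl held fixed, 4-methoxyphenyl in place of 3,5-dichlorophenyl still shifts the number: a 2.3-fold higher number from compound 1 to compound 3 (0.37 log units; beyond the scatter). As far as these compounds go, it remains open whether an amine or a carboxylic acid at this position would act like the added nitro, and whether the gain would persist with 3,5-dichlorophenyl on the urea.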